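Swapping the Saturated Ring on the Pyridine-Linked Pyrazole

The source may hold more compounds than are shown below. What is called first, only, known or untested is meant among the compounds shown, and "the series" means these compounds.

Of the compounds shown here, three sharing one core have been measured in an ADME assay on cells (Hepatocyte, Rattus norvegicus) for metabolic stability, using equilibrium dialysis; on this read-out higher numbers stand for fast clearance and lower numbers for slow clearance. Compound 1, `CC(=O)N[C@@H]1CCC[C@H](C(=O)Nc2cc(-c3cnn4c3CCCC4)c(Cl)cn2)C1`, gives 46 uL/min. Compound 2, `CC(=O)N[C@@H]1CCC[C@H](C(=O)Nc2cc(-c3cnn(C)c3C)c(Cl)cn2)C1`, gives 10 uL/min. Compound 3, `CC(=O)N[C@@H]1CCC[C@H](C(=O)Nc2cc(-c3cnn4c3OCCC4)c(Cl)cn2)C1`, gives 34 uL/min. Among these three numbers compound 3 stands second highest: its nearest neighbour is compound 1, and the pair differ by a 1.4-fold lower number from compound 1 to compound 3 (0.13 log units; within the scatter), while compound 2 lies further off, as a 3.4-fold higher number from compound 2 to compound 3 (0.53 log units; beyond the scatter) shows.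

Compound 4, `CC(=O)N[C@@H]1CCC[C@H](C(=O)Nc2cc(-c3cnn4c3CC(C)(C)C4)c(Cl)cn2)C1`, has not yet been measured. Relative to compound 3 the change is a group of 10 heavy atoms (8 carbon, 2 nitrogen; one five-membered non-aromatic ring with 1 hetero atom, one five-membered aromatic ring with 2 hetero atoms) in place of a group of 9 heavy atoms (6 carbon, 2 nitrogen, 1 oxygen; one five-membered aromatic ring with 2 hetero atoms, one six-membered non-aromatic ring with 2 hetero atoms), on an aromatic carbon.

Two measured steps speak to this change. The exchange of the oxygen-containing six-membered ring for an all-carbon one, a 1.4-fold lower number from compound 1 to compound 3 (0.13 log units; within the scatter), stayed within the scatter. Removing the fused ring altogether, a 4.6-fold lower number from compound 1 to compound 2 (0.66 log units; beyond the scatter), lowered the number modestly, and adding a fused ring back, a 3.4-fold higher number from compound 2 to compound 3 (0.53 log units; beyond the scatter), raised it again. Compound 4 keeps a fused ring and drops the oxygen, so a number close to compound 1 seems the likeliest outcome. The step of a 1.2-fold higher number from compound 3 to compound 4 (0.09 log units; within the scatter) is therefore expected to be small, at most a slight rise. Compound 4 is estimated at 42 uL/min, with a likely range of 18 uL/min to 95 uL/min.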

Compound 4, intrinsic clearance in a liver preparation (reported as CLH), per the amount of preparation that the assay uses: 73 uL/min
The estimate for compound 4 lay 1.7-fold (0.24 log units) below the measured number; measured number inside the range.
By their numbers in this assay, from the lowest: compound 2; then compounds 3, 1 and 4 (each within the scatter of the next, the first and the last beyond it).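

Among the compounds shown here, the step from the oxygen-containing ring to the ring of compound 4 (a 2.1-fold higher number from compound 3 to compound 4 (0.33 log units; beyond the scatter)) is the first to lie beyond the scatter while a fused ring is kept on both sides, so in this assay the kind of fused ring at this position can count, and not only whether one is there. The widest step in the set (a 7.3-fold higher number from compound 2 to compound 4 (0.86 log units; beyond the scatter)) fits the pattern that all three compounds with a fused ring give higher numbers than compound 2, which has none, whereas the two fused rings without oxygen cannot be told apart (a 1.6-fold higher number from compound 1 to compound 4 (0.20 log units; within the scatter)). Nothing available explains these differences.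

Compound 4 differs from compound 3 in ring size, in the oxygen and in its added carbons all at once, so these compounds cannot show which of these changes accounts for the step. From the compounds shown here alone, how a fused ring carrying a hydroxyl group or an amine would behave at this position, or an open ethyl chain in place of a fused ring, also remains open.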